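A few compounds are considered here, and "the series" means these few. Any claim that something is new, unique, unknown or untested is made for them only; others in the source may bear on it.

Two compounds share one core and differ only in the group on the carbonyl carbon. Compound 1 `O=C(NCc1ccc(CNS(=O)(=O)c2ccccc2)cc1)c1c(Cl)cc(Cl)cc1Cl` carries a 2,4,6-trichlorophenyl there, and in an assay on MDA-MB-231 cells for binding affinity to C-X-C chemokine receptor type 4 (Homo sapiens), read by immunofluorescence and microscopy, with stated times of 10 min and 30 min (a higher number here means that more compound is needed for the effect, a lower number that less compound is needed), compound 1 gives 10 nM. Going by the values given here, compound 2 `Cc1ccc(C(=O)NCc2ccc(CNS(=O)(=O)c3ccccc3)cc2)cc1` carries a 4-methylphenyl instead, and in this assay compound 2 gives 100 nM, the higher of the two numbers seen so far, the only comparison being a 10-fold higher number from compound 1 to compound 2 (1.00 log units; beyond the scatter). Compound 3 `O=C(NCc1ccc(CNS(=O)(=O)c2ccccc2)cc1)c1ccncc1` has not yet been measured; its change from compound 2 is pyridin-4-yl in place of 4-methylphenyl on a carbonyl carbon. Among the compounds with values here, the one measured step, from compound 1 to compound 2, concerns a different pair of groups on the same carbonyl carbon and shows only that this position moves the number, not in which direction a pyridin-4-yl would do so. The expected result for compound 3 in this assay is 200 nM, within a range of 50 nM to 800 nM. That estimate means a step of a 2.0-fold higher number from compound 2 to compound 3 (0.30 log units; within the scatter), expected to be modest and uncertain in direction.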

Compound 3, effective concentration (reported as EC, without a stated level of effect): 10 nM
For compound 3 the middle estimate is 20-fold (1.30 log units) above the measured one; the measured number lies below the stated range.
By their numbers in this assay, from the lowest: compounds 1 and 3 (each within the scatter of the next); then compound 2.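

Replacing the 4-methylphenyl with pyridin-4-yl, which brings a ring nitrogen and a hydrogen-bond acceptor, gives a 10-fold lower number from compound 2 to compound 3 (1.00 log units; beyond the scatter) in this assay, so a change at this carbonyl carbon can lower the number as well as raise it. The comparison with the trichlorinated compound shows no change at the digits printed from compound 1 to compound 3 (within the scatter), so among these three compounds a number at this level is reached both with and without chlorine atoms, and only the 4-methylphenyl of compound 2 stands apart. No measurement available here explains why these groups give these numbers.

Going by these compounds, it remains open whether the place of the nitrogen matters, as pyridin-3-yl or pyridin-2-yl would test, and where a plain phenyl would fall. Also open, on these data alone, is how a piperidin-4-yl group or a benzoic acid would read at this carbonyl carbon.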